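The compounds below may be only part of what the source reports. "The series", "measured", "known", "first", "only" and "open" are said of these compounds alone.

Measured so far, each in a functional assay on HCT-116 cells (Homo sapiens) for inhibition, read by sulforhodamine B assay, with a stated time of 72 h; on this read-out higher numbers stand for weaker inhibition and lower numbers for stronger inhibition:
Compound 1 `O=C(/C=C/c1cn(-c2ccccc2)nc1-c1cccnc1)c1cc[nH]c1` gives 7400 nM.
Compound 2 `COc1cc(C(=O)/C=C/c2cn(-c3ccccc3)nc2-c2cccnc2)cc(OC)c1OC` gives 8600 nM.
Compound 3 `O=C(/C=C/c1cn(-c2ccccc2)nc1-c1ccncc1)c1cc[nH]c1` gives 15700 nM.

Compound 1 and compound 3 share a core and differ in one place only: pyridin-4-yl in place of pyridin-3-yl on an aromatic carbon. That change brought a 2.1-fold higher number from compound 1 to compound 3 (0.33 log units; beyond the scatter). Compound 2 differs from compound 1 in more than one place, and the difference between the two cores is not broken down here; the values of compound 2 and compound 1 lie within the usual scatter of each other, so no order between them can be read.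

Compound 4 `COc1cc(C(=O)/C=C/c2cn(-c3ccccc3)nc2-c2ccncc2)cc(OC)c1OC` has not yet been measured. It stands to compound 2 as compound 3 stands to compound 1: pyridin-4-yl in place of pyridin-3-yl on an aromatic carbon. The surroundings of the place are not described word for word alike, since in compound 1 the changed carbon is next to the ring atom that bears a group of 9 heavy atoms, while in compound 2 it is next to the ring atom that bears a large group; this is therefore the same kind of change, not the same one.

If the step repeats, compound 4 is expected to show a 2.0-fold higher number from compound 2 to compound 4 (0.30 log units; within the scatter) in this assay. Among the compounds with values here, this rests on the one earlier step of the same kind, a 2.1-fold higher number from compound 1 to compound 3 (0.33 log units; beyond the scatter). Compound 4 is thus estimated at 17000 nM, expected to fall within 8600 nM to 35000 nM.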

Compound 4, half-maximal inhibitory concentration: 300 nM
The estimate for compound 4 lay 57-fold (1.75 log units) above the measured number, and the stated range ends above it.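

In this assay, the swap of pyridin-3-yl for pyridin-4-yl gave a 29-fold lower number from compound 2 to compound 4 (1.46 log units; beyond the scatter), and this step does not match the one seen on the other core: the same change on two cores in this assay, a 2.1-fold higher number (0.33 log units; beyond the scatter) from compound 1 to compound 3 and a 29-fold lower number (1.46 log units; beyond the scatter) from compound 2 to compound 4, 61-fold (1.78 log units) apart, beyond the scatter of two such steps So in this series, the result of this change depends on the core that carries it, and a step measured on one core gave no safe forecast for the other. What the four compounds do not show is why the two cores part ways, since they differ in more than one place and each step rests on a single pair of compounds.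

The compounds shown leave open how pyridin-2-yl would behave at the same place on either core. They also leave open which part of the core of compound 2 goes with the large step, for instance whether a core with a single methoxy group, or with an amine in its place, would behave like compound 2 or like compound 1.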